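A few compounds are considered here, and "the series" means these few. Any claim that something is new, unique, unknown or untested is made for them only; others in the source may bear on it.

Compound 1 `CC1=C(/C=C/C(=O)/C=C/c2ccc(Cl)cc2)C(C)(C)CCC1` is a chalcone-like diene carrying a chloro group on its phenyl ring, and in a functional assay on PC-3 cells (Homo sapiens) for cytotoxicity, read by sulforhodamine B assay, with a stated time of 48 h (a lower number here means a stronger inhibitor, a higher number a weaker inhibitor), compound 1 gives 9500 nM. For the measured compounds named here, of the three numbers known so far, that of compound 1 sits second highest, yet its steps to both neighbours are within the scatter. Compound 2 `CC1=C(/C=C/C(=O)/C=C/c2ccc(F)cc2)C(C)(C)CCC1` gives 8200 nM in this assay, and compound 3 `CC1=C(/C=C/C(=O)/C=C/c2ccc(C#N)cc2)C(C)(C)CCC1` gives 11900 nM. The three measured steps, a 1.2-fold lower number from compound 1 to compound 2 (0.06 log units; within the scatter), a 1.3-fold higher number from compound 1 to compound 3 (0.10 log units; within the scatter) and a 1.5-fold higher number from compound 2 to compound 3 (0.16 log units; within the scatter), all stay within the scatter, so swapping the group on that aromatic carbon among chloro, fluoro and cyano has left the read-out essentially unchanged.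

Compound 4 `COc1ccc(/C=C/C(=O)/C=C/C2=C(C)CCCC2(C)C)cc1` differs from compound 1 by methoxy in place of chloro on an aromatic carbon. Going by the values given here, none of the measured steps touches a methoxy group, but all three bear on the same position and were flat. On that basis no step beyond the scatter is expected, and the step from compound 1 to compound 4 is estimated as a 1.1-fold higher number from compound 1 to compound 4 (0.02 log units; within the scatter). Compound 4 is therefore expected to give about 10000 nM in this assay, within a range of 5000 nM to 20000 nM.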

Compound 4, half-maximal inhibitory concentration: 58700 nM
Beside the measured number, compound 4's estimate is 5.9-fold (0.77 log units) below it, outside the stated range (above it).
By their numbers in this assay, from the lowest: compounds 2, 1 and 3 (each within the scatter of the next); then compound 4.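

The position on this aromatic carbon is not indifferent after all: in this assay methoxy in place of chloro gives a 6.2-fold higher number from compound 1 to compound 4 (0.79 log units; beyond the scatter) and methoxy in place of cyano gives a 4.9-fold higher number from compound 3 to compound 4 (0.69 log units; beyond the scatter) while methoxy in place of fluoro gives a 7.2-fold higher number from compound 2 to compound 4 (0.85 log units; beyond the scatter). Chloro, fluoro and cyano remain within the scatter of one another, so methoxy alone separates from the set, and compound 4 is the weakest of the four, with its steps to all three others beyond the scatter. Nothing available accounts for why methoxy departs from the other three groups.

The compounds shown leave open whether this weakening is confined to methoxy or extends to other groups on this carbon, such as a hydroxyl, an amine or an ethoxy group. They also leave open whether a plain methyl group, which lacks the oxygen of methoxy, would stay with the flat set or move with compound 4.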